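This account rests on a few compounds, and the source may have more. Where it says the series, first, only, none or still open, it means among the compounds named here.

In a functional assay on MDA-MB-231 cells (Homo sapiens) for antiproliferative activity, read by sulforhodamine B assay, with a stated time of 72 h (a lower number here means a stronger inhibitor, a higher number a weaker inhibitor), compound 1 `CC(C)C[C@H](NC(=O)CSc1cc(NS(=O)(=O)c2ccccc2)c2ccccc2c1O)B(O)O` gives 10600 nM. Compound 2 `CC(C)C[C@H](NC(=O)CSc1cc(NS(=O)(=O)c2ccc(Cl)cc2)c2ccccc2c1O)B(O)O` differs from it in one place, (chloro in place of hydrogen on an aromatic carbon), and in this assay compound 2 gives 6190 nM, so that the step is a 1.7-fold lower number from compound 1 to compound 2 (0.23 log units; within the scatter). Compound 3 `CC(C)C[C@H](NC(=O)CCSc1cc(NS(=O)(=O)c2ccccc2)c2ccccc2c1O)B(O)O` is built on another core; the difference between the two cores is not broken down here. In this assay compound 3 gives 4200 nM; its gap to compound 1 lies beyond the scatter, while its gap to compound 2 lies within it. Compound 4 `CC(C)C[C@H](NC(=O)CCSc1cc(NS(=O)(=O)c2ccc(Cl)cc2)c2ccccc2c1O)B(O)O` has not yet been measured. It stands to compound 3 as compound 2 stands to compound 1: the change is chloro in place of hydrogen on an aromatic carbon, and the place described for it matches the earlier one word for word, so this is the same change, seen twice among these four compounds. On that single earlier example the expected step is a 1.7-fold lower number from compound 3 to compound 4 (0.23 log units; within the scatter), a guess that rests on compound 1 and compound 2 because a 1.7-fold lower number from compound 1 to compound 2 (0.23 log units; within the scatter) was observed and lay within the scatter. Compound 4 is therefore expected to give about 2500 nM in this assay, with a likely range from 1200 nM to 5500 nM.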

Compound 4, half-maximal inhibitory concentration: 4090 nM
Beside the measured number, compound 4's estimate is 1.6-fold (0.21 log units) below it; the measured number falls inside the stated range.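

In this assay, putting chloro in place of hydrogen on the phenyl ring gives a 1.0-fold lower number from compound 3 to compound 4 (0.01 log units; within the scatter), and the two examples of this change do not differ from each other: the same change on two cores in this assay, a 1.7-fold lower number (0.23 log units; within the scatter) from compound 1 to compound 2 and a 1.0-fold lower number (0.01 log units; within the scatter) from compound 3 to compound 4, 1.7-fold (0.22 log units) apart, within the scatter of two such steps Neither step lies beyond the scatter, so the change can be said to carry over between these two cores only in the sense that it stays small on both, and two pairs cannot show whether the chloro has a small real effect or none. The step between the two chloro compounds, which differ in the group on the sulfur, is also small, at a 1.5-fold lower number from compound 2 to compound 4 (0.18 log units; within the scatter).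

From the compounds shown here alone, it remains open whether a methoxy group, an amine or a carboxylic acid at the same place on the ring would move the number beyond the scatter, and whether such a larger step would carry from one core to the other. Going by these compounds, a still longer chain on the sulfur is also open.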